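The source may report more compounds than this note shows. Statements on the series, on what has been measured and on what is new or still open speak of the compounds shown alone.

Measured compounds:
compound 1, `CC(C)(C)[C@H]1CC[C@]2(CC1)N=C(c1ccc(C(F)(F)F)cc1)C(=O)N2Cc1ccc(C(=O)NCCC(=O)O)cc1`, 800 nM
compound 2, `CC(C)(C)CC[C@H](c1ccc(C(=O)NCc2nn[nH]n2)cc1)N1C(=O)C(c2ccc(C(F)(F)F)cc2)=N[C@]12CC[C@@H](C(C)(C)C)CC2`, 160 nM

Both numbers come from a functional assay on CHO cells for antagonist activity at Glucagon receptor (Homo sapiens), read by cAMP accumulation, with stated times of 30 min and 45 min; a higher number here means a weaker inhibitor, a lower number a stronger inhibitor. Compound 1 stands at the higher of the two values; compound 2 gives 160 nM, and the gap between compound 1 and compound 2 lies beyond the usual scatter. The two compounds differ in several places at once, so no single change can be read out of that gap.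

Compound 3, `CC(C)(C)[C@H]1CC[C@]2(CC1)N=C(c1ccc(Cl)cc1)C(=O)N2Cc1ccc(C(=O)NCCC(=O)O)cc1`, has not yet been measured in this assay. It differs from compound 1 in one place only: chloro in place of trifluoromethyl on an aromatic carbon. The rest of the shared core and the acid-bearing side chain on the benzylic amide are unchanged. Within the data shown here, no pair among the measured compounds shows this change on its own, so no step for it is known.

The expectation is that the step from compound 1 to compound 3 in this assay is small, a 1.4-fold higher number from compound 1 to compound 3 (0.14 log units; within the scatter), with no clear direction beyond the scatter, perhaps leaning toward a slightly higher number. Compound 3 is estimated at 1100 nM, within a range of 400 nM to 3200 nM.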

Compound 3, half-maximal inhibitory concentration: 1400 nM
Compound 3: the middle estimate sits 1.3-fold (0.10 log units) below what was measured; the range from low to high includes it.
By their numbers in this assay, from the lowest: compound 2; then compounds 1 and 3 (each within the scatter of the next).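

In this assay, among these compounds, chloro in place of trifluoromethyl on an aromatic carbon, para to a large group, gives a 1.8-fold higher number from compound 1 to compound 3 (0.24 log units; within the scatter), the first step that isolates a single place. At this position, 4-(trifluoromethyl)phenyl and 4-chlorophenyl therefore cannot be told apart in this read-out, even though a group of 4 heavy atoms gives way to a single chlorine atom with the acid-bearing side chain and the rest of the shared core unchanged. Nothing on hand explains this outcome or ties it to any property of either group.

The compounds shown leave open whether any other group at this position, such as hydrogen, a methoxy group, a nitrile, an amine or a carboxylic acid, would move the number beyond the scatter. Also open, from the compounds shown here alone, is whether chloro in place of trifluoromethyl would give a step of similar size on compound 2, and which of the several differences between compound 1 and compound 2 accounts for the gap between them.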